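The compounds below may be only part of what the source reports. "The series", "measured", "known", "first", "only" and "open" are said of these compounds alone.

In an assay on cells for displacement of a labelled ligand from prostaglandin E2 receptor EP4 subtype (Homo sapiens), read by scintillation counting (on this read-out lower numbers stand for stronger inhibition and higher numbers for weaker inhibition), compound 1 `Cc1oc(C(=O)O)cc1COc1ccc(-c2ccc(Cl)cc2)cc1` gives 1000 nM, the highest of the three numbers measured. Compound 2 `COc1ccc(-c2ccc(OCc3cc(C(=O)NS(=O)(=O)c4ccc(CN)cc4)oc3C)cc2)cc1` gives 100 nM, and compound 3 `COc1ccc(-c2ccc(OCc3cc(C(=O)NS(=O)(=O)c4ccccc4)oc3C)cc2)cc1` gives 5 nM. Within the data shown here, the only step measured between neighbouring compounds, a 20-fold lower number from compound 2 to compound 3 (1.30 log units; beyond the scatter), concerns a different part of the shared core and says nothing about the 4-chlorophenyl to phenyl change. Compound 4 `Cc1oc(C(=O)O)cc1COc1ccc(-c2ccccc2)cc1` differs from compound 1 by hydrogen in place of chloro on an aromatic carbon. Among the measured compounds shown here, no measured step bears directly on this change, so the expectation rests on the change alone. A small rise in the number, not far beyond the scatter, is expected, a 1.8-fold higher number from compound 1 to compound 4 (0.26 log units; within the scatter). Compound 4 is therefore estimated to give about 1800 nM, with a range from 600 nM to 6000 nM.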

Compound 4, inhibition constant: 420 nM
The estimate for compound 4 lay 4.3-fold (0.63 log units) above the measured number; the whole stated range lies above it.
By their numbers in this assay, from the lowest: compound 3; then compound 2; then compound 4; then compound 1.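

In this assay, hydrogen in place of chloro on this aromatic carbon, para to a large group, gives a 2.4-fold lower number from compound 1 to compound 4 (0.38 log units; beyond the scatter), so on this core the chloro is not needed for the lower number. Among these compounds, this is the first reading at this position, as no earlier pair of compounds differed there alone. Nothing available explains the step.

Open, as far as these compounds go, is whether fluoro or a nitrile at this place would lower the number further. Also open, from the compounds shown here alone, is whether the same change would hold on the core of compound 3, which differs from compound 4 in more than one place.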